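A few compounds are considered here, and "the series" means these few. Any claim that something is new, unique, unknown or untested is made for them only; others in the source may bear on it.

Going by the values given here, compound 3 `NC(=O)[C@@H](CCC(F)(F)F)N(C[C@H]1CCCCO1)S(=O)(=O)c1ccc(Cl)cc1` gives 4.3 in a physicochemical assay for lipophilicity, read by HPLC, measured as octanol-water partition, at pH 7.4 (a higher number here means a more lipophilic compound, a lower number a more polar compound), the highest of the three numbers measured so far. Compound 2 `CC1(C)C[C@@H](CN([C@H](CCC(F)(F)F)C(N)=O)S(=O)(=O)c2ccc(Cl)cc2)O1` gives 3.8, and compound 1 `NC(=O)[C@@H](CCC(F)(F)F)N(CC1COC1)S(=O)(=O)c1ccc(Cl)cc1` gives 2.5; the step of a number 0.50 log units higher from compound 2 to compound 3 (beyond the scatter) and the step of a number 1.80 log units higher from compound 1 to compound 3 (beyond the scatter) both ran upward. Compound 4 `NC(=O)[C@@H](CCC(F)(F)F)N(C[C@@H]1CCCCO1)S(=O)(=O)c1ccc(Cl)cc1` is the next case. (the two compounds have the same atoms and bonds and differ only in configuration as drawn: 1 of 2 stereo elements differ; a stereocentre at a saturated ring carbon is drawn R in compound 3 and S in compound 4). Among the compounds with values here, none of the measured steps concerns a change of configuration alone; each swapped one ring for another, as in a number 1.30 log units higher from compound 1 to compound 2 (beyond the scatter). Since compound 4 keeps every atom and bond of compound 3, the expected step of no change at the digits printed from compound 3 to compound 4 (within the scatter) is small, within the scatter, in no particular direction. Compound 4 is therefore expected to give 4.3, in a range from 4 to 4.6.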

Compound 4, distribution coefficient: 4.3
Compound 4: middle estimate and measured number agree at the digits printed; low and high end bracket the measured number.
By their numbers in this assay, from the lowest: compound 1; then compound 2; then compounds 3 and 4 (each within the scatter of the next).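

Reversing the stereocentre at the saturated ring carbon of the oxan-2-yl group gives no change at the digits printed from compound 3 to compound 4 (within the scatter) in this assay and so, unlike the ring swaps before it, leaves the number in place. With the other configuration, the ring swaps keep their size: a number 0.50 log units higher from compound 2 to compound 4 (beyond the scatter) for oxan-2-yl in place of 4,4-dimethyloxetan-2-yl and a number 1.80 log units higher from compound 1 to compound 4 (beyond the scatter) for oxan-2-yl in place of oxetan-3-yl. This pair gives a clean reading of configuration alone: the fact that compounds 3 and 4 differ only in the configuration as drawn

Still open, as far as these compounds go, is whether configuration matters as little when the oxan-2-yl ring carries an amine or a carboxylic acid.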